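The source may hold more compounds than are shown below. What is called first, only, known or untested is meant among the compounds shown, and "the series" means these compounds.

In an assay on cell membranes for binding affinity to Fatty-acid amide hydrolase 1 (Rattus norvegicus) (on this read-out higher numbers stand for weaker inhibition and lower numbers for stronger inhibition), compound 1 `O=C(NC1CCCCC1)Oc1cccc(-c2cccc(Oc3ccccc3)c2)c1` gives 420 nM, and compound 2 `O=C(NC1CCCCC1)Oc1cccc(-c2cccc(-c3ccccc3)c2)c1` gives 565 nM.

Compound 2 thus holds the higher of the two numbers, with compound 1 within the scatter of it: a 1.3-fold higher number from compound 1 to compound 2 (0.13 log units; within the scatter). Compound 3 `O=C(NC1CCCCC1)Oc1cccc(-c2cccc(CCO)c2)c1` differs from compound 2 by 2-hydroxyethyl in place of phenyl on an aromatic carbon. Among the compounds with values here, the one measured step exchanges phenoxy for phenyl, so no measured step bears directly on trading phenyl for 2-hydroxyethyl. With no guide beyond that, the step in this assay is expected to be a 1.3-fold lower number from compound 2 to compound 3 (0.10 log units; within the scatter), and this expectation carries wide uncertainty. Compound 3 is estimated at 450 nM, between 120 nM and 1700 nM.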

Compound 3, half-maximal inhibitory concentration: 18.7 nM
Estimate against measurement, compound 3: 24-fold (1.38 log units) above, outside the stated range (below it).
By their numbers in this assay, from the lowest: compound 3; then compounds 1 and 2 (each within the scatter of the next).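

This position is clearly sensitive to what sits on it. Phenoxy and phenyl read alike, yet 2-hydroxyethyl, which has no ring, gives a 30-fold lower number from compound 2 to compound 3 (1.48 log units; beyond the scatter) and a 22-fold lower number from compound 1 to compound 3 (1.35 log units; beyond the scatter). No measurement at hand explains this gain in inhibition.

The compounds shown leave open whether the step comes from losing the aromatic ring or from gaining the hydroxyl group. They also leave open whether a plain ethyl group, a longer chain ending in hydroxyl, or an amine in the same place would do as well.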